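Aryl swap on the saturated ring carbon: cytotoxicity outlook

The source may report more compounds than this note shows. Statements on the series, on what has been measured and on what is new or still open speak of the compounds shown alone.

Compound 3 `CC1=C(C(=O)Nc2ccc(Cl)cc2)C(c2ccccc2O)C(C(=O)Nc2ccc(Cl)cc2)=C(C)N1` in an ADME assay on Vero cells (Chlorocebus sabaeus) for cytotoxicity, read by sulforhodamine B assay, with a stated time of 3 days (a lower number here means that less compound is tolerated, a higher number that more compound is tolerated), gives 62 ug/mL, the second highest of the three numbers. Compound 1 `COc1cc(C2C(C(=O)Nc3ccc(Cl)cc3)=C(C)NC(C)=C2C(=O)Nc2ccc(Cl)cc2)ccc1O` gives 250 ug/mL in this assay, with the step of a 4.0-fold lower number from compound 1 to compound 3 (0.61 log units; beyond the scatter). Compound 2 `CC1=C(C(=O)Nc2ccc(Cl)cc2)C(c2cccc(Cl)c2)C(C(=O)Nc2ccc(Cl)cc2)=C(C)N1` gives 12 ug/mL, with the step of a 5.2-fold higher number from compound 2 to compound 3 (0.71 log units; beyond the scatter).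

Compound 4 `CC1=C(C(=O)Nc2ccc(Cl)cc2)C(c2ccc(N(C)C)cc2)C(C(=O)Nc2ccc(Cl)cc2)=C(C)N1` differs from compound 3 in one place: 4-(dimethylamino)phenyl in place of 2-hydroxyphenyl on a saturated ring carbon. Every measured step in the series bears on this position, since each exchanges the aryl group on the saturated ring carbon: a 21-fold lower number from compound 1 to compound 2 (1.32 log units; beyond the scatter), a 5.2-fold higher number from compound 2 to compound 3 (0.71 log units; beyond the scatter) and a 4.0-fold lower number from compound 1 to compound 3 (0.61 log units; beyond the scatter). These steps range from modest to large, so a change beyond the scatter is plausible, but none of them involves a dimethylamino group, so the direction is open. A modest step is expected, a 1.2-fold lower number from compound 3 to compound 4 (0.09 log units; within the scatter), with the outcome uncertain in either direction. Compound 4 is estimated at 50 ug/mL in this assay, within a range from 15 ug/mL to 200 ug/mL.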

Compound 4, half-maximal cytotoxic concentration: 155 ug/mL
Compound 4: middle estimate off by 3.1-fold (0.49 log units), on the low side, within the range that was stated.
By their numbers in this assay, from the lowest: compound 2; then compound 3; then compounds 4 and 1 (each within the scatter of the next).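

In this assay the position accepts 4-(dimethylamino)phenyl, which has no hydroxyl, with a 2.5-fold higher number from compound 3 to compound 4 (0.40 log units; beyond the scatter) and a 13-fold higher number from compound 2 to compound 4 (1.11 log units; beyond the scatter), so a hydroxyl on this aryl group is not needed for a high number. With a 1.6-fold lower number from compound 1 to compound 4 (0.21 log units; within the scatter), two quite different aryl groups now share the high end, and the three hydroxyl-free or hydroxyl-bearing comparisons give no single order: compound 2 and compound 4 both lack a hydroxyl yet lie furthest apart. Nothing at hand explains these differences.

As far as these compounds go, it remains open whether the dimethylamino group itself or its place on the ring sets the number. A 4-chlorophenyl group, set against the 3-chlorophenyl of compound 2, and a plain phenyl group at this carbon would help separate the two.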